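The source may report more compounds than this note shows. Statements on the series, on what has been measured and on what is new or still open speak of the compounds shown alone.

Compound 1, `CCOC(=O)N1CCC[C@H](S(=O)(=O)c2ccc(S(=O)(=O)N(CC)CC)cc2)C1`, in a functional assay on MIA PaCa-2 cells (Homo sapiens) for inhibition, read by MTT assay, with a stated time of 7 days (a lower number here means a stronger inhibitor, a higher number a weaker inhibitor), returns only a limit, > 30000 nM.
Compound 2, `CCN(CC)S(=O)(=O)c1ccc(S(=O)(=O)N2CCC[C@@H](C(=O)N(C)C(C)C)C2)cc1`, in this assay gives 6200 nM.
Compound 3, `CCOC(=O)C1CCCCN1S(=O)(=O)c1ccc(S(=O)(=O)N(CC)CC)cc1`, in this assay gives 24600 nM.

Among the two compounds that give a number, compound 2 stands lowest; compound 3 gives the higher number, and the gap between the two lies beyond the usual scatter. The value of compound 1 is a limit and not a number. the limit of > 30000 nM in this assay, at which 1 of the 3 values shown sits, marks that limit.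

Compound 4, `CCN1CC(NC(=O)[C@@H]2CCCN(S(=O)(=O)c3ccc(S(=O)(=O)N(CC)CC)cc3)C2)C1`, differs from compound 2 in one place: (1-ethylazetidin-3-yl)amino in place of isopropyl(methyl)amino on a carbonyl carbon. For the measured compounds named here, no measured pair shows this kind of exchange, so the account can say only what compound 2 itself shows. The step from compound 2 to compound 4 is expected to be small, in either direction, and is estimated as a 1.1-fold lower number from compound 2 to compound 4 (0.05 log units; within the scatter), which is within the scatter of this assay. Compound 4 is therefore expected to give about 5500 nM in this assay, with a likely range from 1500 nM to 20000 nM.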

Compound 4, half-maximal inhibitory concentration: > 30000 nM
Compound 4: only a limit was reported (the forecaster's own chance of this, stated with the estimate: 15%); middle value at least 5.4-fold (0.73 log units) from the limit.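

For the compounds shown here, the step gives the first reading of a change at this position, since the earlier compounds held no pair differing in one place: (1-ethylazetidin-3-yl)amino in place of isopropyl(methyl)amino on the carbonyl carbon gives an at least 4.8-fold higher number from compound 2 to compound 4 (0.68 log units; beyond the scatter) in this assay. The group on this carbonyl carbon therefore matters to the number, and this exchange moves it upward. Compound 4 is reported only as a limit, so the step fixes a direction and a minimum size but not a full size: the limit of > 30000 nM in this assay, at which 2 of the 4 values shown sit.

Which part of the entering group carries this rise stays open, as a four-membered ring, a hydrogen-bond donor and a hydrogen-bond acceptor enter together. Also open, from the compounds shown here alone, is how a simple isopropylamino group or a piperidin-1-yl group on the same carbonyl carbon would compare with compound 2.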